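A few compounds are considered here, and "the series" means these few. Any claim that something is new, unique, unknown or untested is made for them only; others in the source may bear on it.

Working notes on the series. Compound 2 `Cc1nc(C)c(CN2CCN(c3cccc4[nH]c(-c5ccc(C(C)(C)C)cc5)nc34)CC2)s1` gives 27 nM in an assay on isolated protein for displacement of a labelled ligand from Gonadotropin-releasing hormone receptor (Homo sapiens) (a higher number here means a weaker inhibitor, a lower number a stronger inhibitor), the second highest of the three numbers in hand. Compound 3 `Cc1nc(CN2CCN(c3cccc4[nH]c(-c5ccc(C(C)(C)C)cc5)nc34)CC2)cn1C` gives 10 nM, and compound 1 `Cc1ccc(CN2CCN(c3cccc4[nH]c(-c5ccc(C(C)(C)C)cc5)nc34)CC2)o1` gives 705 nM. The steps of a 26-fold lower number from compound 1 to compound 2 (1.42 log units; beyond the scatter) and a 71-fold lower number from compound 1 to compound 3 (1.85 log units; beyond the scatter) are both large, while a 2.7-fold lower number from compound 2 to compound 3 (0.43 log units; beyond the scatter) is modest.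

Compound 4 `CCc1nc(CN2CCN(c3cccc4[nH]c(-c5ccc(C(C)(C)C)cc5)nc34)CC2)cn1C` differs from compound 2 in one place: 2-ethyl-1-methyl-1H-imidazol-4-yl in place of 2,4-dimethyl-1,3-thiazol-5-yl on a saturated chain carbon bound to an amine nitrogen in a ring. The step from compound 2 to compound 3 is the one that bears on this change, since compound 4 carries the same imidazolyl ring as compound 3 with an ethyl in place of one methyl. A modest lowering of the number in this assay is therefore expected, about a 2.3-fold lower number from compound 2 to compound 4 (0.35 log units; beyond the scatter). Compound 4 is expected to give roughly 12 nM, within 4 nM to 35 nM.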

Compound 4, half-maximal inhibitory concentration: 18 nM
Compound 4: middle estimate off by 1.5-fold (0.18 log units), on the low side; the measured number falls inside the stated range.
By their numbers in this assay, from the lowest: compounds 3, 4 and 2 (each within the scatter of the next, the first and the last beyond it); then compound 1.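

Adding a methyl to the chain carbon on the imidazolyl ring leaves the reading within the scatter, at a 1.8-fold higher number from compound 3 to compound 4 (0.26 log units; within the scatter) here. The thiazolyl-to-imidazolyl change with the ethyl group also stays within the scatter, at a 1.5-fold lower number from compound 2 to compound 4 (0.18 log units; within the scatter) in this case. The large separation from the furan persists with the ethyl group in place, at a 39-fold lower number from compound 1 to compound 4 (1.59 log units; beyond the scatter) overall.

Going by these compounds, whether a propyl chain or an amine at the ethyl position would keep these numbers stays open. Nothing measured here accounts for these steps.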